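The source may report more compounds than this note shows. Statements on the series, on what has been measured and on what is new or still open speak of the compounds shown alone.

Measured compounds:
- compound 1, `CC(=O)N1CCN([C@H]2CC[C@H](Nc3ncnc4[nH]cc(C5CCOCC5)c34)CC2)CC1`: 3 10^-6 cm/s
- compound 2, `CS(=O)(=O)N1CCN([C@H]2CC[C@H](Nc3ncnc4[nH]cc(C5CCOCC5)c34)CC2)CC1`: 5 10^-6 cm/s

In an ADME assay on Caco-2 cells (Homo sapiens) for permeability, tested at 10 uM (a higher number here means that the compound crosses the layer faster, a lower number that the compound crosses the layer more slowly), compound 2 gives the higher of the two numbers, but its distance from compound 1 is small: a 1.7-fold higher number from compound 1 to compound 2 (0.22 log units; within the scatter), a change that does not rise above the scatter, so the two cannot be ordered.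

Compound 3, `CN(C)C(=O)C1CCN([C@H]2CC[C@H](Nc3ncnc4[nH]cc(C5CCOCC5)c34)CC2)CC1`, has not yet been measured. Relative to compound 2 its change is 4-(dimethylcarbamoyl)piperidin-1-yl in place of 4-(methylsulfonyl)piperazin-1-yl on a saturated ring carbon. For the measured compounds named here, the one measured step that touches this part of the molecule is the acetyl-to-methylsulfonyl exchange, a 1.7-fold higher number from compound 1 to compound 2 (0.22 log units; within the scatter), which shows that trading an amide for a sulfonyl on the ring nitrogen moved nothing beyond the scatter. The change to compound 3 is larger in kind, since the ring itself is altered and the dimethylcarbamoyl group now sits on a ring carbon, but nothing in the two measured compounds points to a direction. The expected step is therefore a 1.2-fold higher number from compound 2 to compound 3 (0.08 log units; within the scatter), within the scatter.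

Compound 3 is accordingly estimated at 6 10^-6 cm/s, with a range from 2.5 10^-6 cm/s to 14 10^-6 cm/s.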

Compound 3, apparent permeability: < 1 10^-6 cm/s
Compound 3 ended at the assay's limit; the forecaster's own chance of this, stated with the estimate: 5%; middle value at least 6.0-fold (0.77 log units) away from the limit.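

In this assay, the large group on the saturated ring carbon turns out to matter: 4-(dimethylcarbamoyl)piperidin-1-yl in place of 4-(methylsulfonyl)piperazin-1-yl gives an at least 5.0-fold lower number from compound 2 to compound 3 (0.69 log units; beyond the scatter), and in place of 4-acetylpiperazin-1-yl it gives an at least 3.0-fold lower number from compound 1 to compound 3 (0.47 log units; beyond the scatter). For the compounds shown here, these are the first steps at this position to rise above the scatter, whereas the exchange of acetyl for methylsulfonyl on the piperazine nitrogen gave only a 1.7-fold higher number from compound 1 to compound 2 (0.22 log units; within the scatter). Compound 3 gives < 1 10^-6 cm/s, which is a limit of the assay and not a number, so both new steps are minimum sizes and their full extent stays unknown: the limit of < 1 10^-6 cm/s in this assay, at which 1 of the 3 values shown sits.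

The replacement alters the ring and the attached group in a single step, moving from a ring with 2 hetero atoms to one with 1 and from a nitrogen-bound group to a carbon-bound dimethylcarbamoyl, and the compounds shown cannot separate these parts. As far as these compounds go, a piperazine with dimethylcarbamoyl on its ring nitrogen, or a piperidine with methylsulfonyl or acetyl on the ring carbon, would show which part goes with the lower number, while the effect of an amine or a carboxylic acid at this position remains open.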